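Saturating the Amide Side Chain of a Trimethoxyanilide

A few compounds are considered here, and "the series" means these few. Any claim that something is new, unique, unknown or untested is made for them only; others in the source may bear on it.

Compound 1, `COc1ccc(CNc2cc(OC)c(OC)c(OC)c2)cc1[N+](=O)[O-]`, gives 19400 nM in a functional assay on MGC-803 cells (Homo sapiens) for inhibition, read by MTT assay, with a stated time of 48 h; a higher number here means a weaker inhibitor, a lower number a stronger inhibitor.
Compound 2, `COc1ccc(CN(C(=O)C=C(C)C)c2cc(OC)c(OC)c(OC)c2)cc1O`, gives 320 nM in this assay.
Compound 3, `COc1ccc(CNc2cc(OC)c(OC)c(OC)c2)cc1N`, gives 7970 nM in this assay.

Among these three, compound 2 stands lowest in this assay; its value lies well below that of compound 3, and further still below that of compound 1, both gaps beyond the scatter. For the measured compounds named here, the one measured step that changes a single place, a 2.4-fold lower number from compound 1 to compound 3 (0.39 log units; beyond the scatter), concerns a substituent on the aromatic ring of the benzyl part and leaves the nitrogen bearing a hydrogen; it tells nothing about what happens at the amide carbonyl.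

Compound 4, `COc1ccc(CN(C(=O)C(C)C)c2cc(OC)c(OC)c(OC)c2)cc1O`, is the next compound to be measured. It differs from compound 2 in one place: isopropyl in place of 2-methylprop-1-en-1-yl on a carbonyl carbon. Going by the values given here, no measured step touches this carbonyl substituent, so the expectation for compound 4 rests on compound 2 alone, whose value in this assay is 320 nM. A modest rise in the number is expected, a 3.1-fold higher number from compound 2 to compound 4 (0.49 log units; beyond the scatter), since the double bond outside the aromatic rings is lost. Compound 4 is thus estimated at 1000 nM in this assay, with a range from 300 nM to 4000 nM.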

Compound 4, half-maximal inhibitory concentration: 210 nM
Estimate against measurement, compound 4: 4.8-fold (0.68 log units) above; the measured number lies below the stated range.
By their numbers in this assay, from the lowest: compounds 4 and 2 (each within the scatter of the next); then compound 3; then compound 1.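

In this assay, for the compounds shown here, the substituent on a carbonyl carbon whose other neighbour is the amide-type nitrogen is varied here for the first time, and isopropyl in place of 2-methylprop-1-en-1-yl gives a 1.5-fold lower number from compound 2 to compound 4 (0.18 log units; within the scatter), so the two compounds cannot be told apart. For this one pair, the double bond outside the aromatic rings is therefore not required for a value at this level, and the saturated, shorter isopropyl group serves as well as the unsaturated group it replaces. Nothing measured here accounts for this outcome, and no supporting evidence bears on it.

What the compounds shown leave open is how much this carbonyl substituent can vary before the number moves beyond the scatter, for instance with a small methyl group, a cyclopropyl ring, a longer chain such as n-pentyl, or a chain ending in an amine or a carboxylic acid. From the compounds shown here alone, the part played by the carbonyl itself also stays open, since compound 1 and compound 3 differ from compound 2 and compound 4 in more than one place and offer no single-place comparison.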